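Adding a Third Methoxy Group: From Compound 2 to Compound 3

The compounds below may be only part of what the source reports. "The series", "measured", "known", "first", "only" and "open" are said of these compounds alone.

Two compounds sharing one core have been measured in a functional assay on A549 cells (Homo sapiens) for inhibition, read by MTT assay, with a stated time of 48 h; on this read-out lower numbers stand for stronger inhibition and higher numbers for weaker inhibition:

compound 1 `COc1cc(-c2nc3cc(/C=C4\SC(=O)N(CC(=O)N5CCOCC5)C4=O)ccc3[nH]2)cc(OC)c1OC` — 2930 nM
compound 2 `COc1ccc(-c2nc3cc(/C=C4\SC(=O)N(CC(=O)N5CCOCC5)C4=O)ccc3[nH]2)cc1OC` — 8930 nM

For the measured compounds named here, compound 2 stands at the higher of these two numbers; its nearest neighbour is compound 1, and the only measured step, a 3.0-fold higher number from compound 1 to compound 2 (0.48 log units; beyond the scatter), is the removal of one methoxy group. Compound 3 `COc1cc(OC)c(-c2nc3cc(/C=C4\SC(=O)N(CC(=O)N5CCOCC5)C4=O)ccc3[nH]2)cc1OC` has not yet been measured. It differs from compound 2 by the change (methoxy in place of hydrogen on an aromatic carbon), so compound 3 again carries three methoxy groups, though not arranged as in compound 1.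

Going by the values given here, the single step that bears on this change, a 3.0-fold higher number from compound 1 to compound 2 (0.48 log units; beyond the scatter), runs the other way: there a methoxy leaves and the number rises, so read in reverse, a methoxy entering lowers the number by that same amount. Among the compounds with values here, a methoxy entering at a different place need not repeat that, yet it is the only guide available. A modest fall in this assay is therefore expected for compound 3, of about a 2.2-fold lower number from compound 2 to compound 3 (0.35 log units; beyond the scatter). Compound 3 is estimated at 4000 nM, with a range from 1200 nM to 13000 nM.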

Compound 3, half-maximal inhibitory concentration: 660 nM
Compound 3: middle estimate off by 6.1-fold (0.78 log units), on the high side, outside the stated range (below it).
By their numbers in this assay, from the lowest: compound 3; then compound 1; then compound 2.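

In this assay, a methoxy group entering on the aromatic carbon ortho to a large group, meta to one methoxy group and para to another, gives a 14-fold lower number from compound 2 to compound 3 (1.13 log units; beyond the scatter). That step is classed as large, whereas the loss of a methoxy group elsewhere gave the modest step of a 3.0-fold higher number from compound 1 to compound 2 (0.48 log units; beyond the scatter), so in these compounds the size of the change depends on which carbon is involved and not merely on whether a methoxy group is present. Compounds with the same number of methoxy groups also part clearly, with 2,4,5-trimethoxyphenyl in place of 3,4,5-trimethoxyphenyl giving a 4.4-fold lower number from compound 1 to compound 3 (0.65 log units; beyond the scatter), and nothing measured here accounts for this difference.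

The compounds shown leave open whether this carbon needs a methoxy group in particular, or whether a hydroxy group, a fluorine atom or an ethoxy group there would give a similar number. They also leave open whether the 2,4,5-trimethoxyphenyl group would keep its place ahead of the other two groups if the shared core carried an amine or a carboxylic acid in place of its present side chain.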